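From Methoxy to Ethylsulfanyl on a Shared Core

A few compounds are considered here, and "the series" means these few. Any claim that something is new, unique, unknown or untested is made for them only; others in the source may bear on it.

In a physicochemical assay for lipophilicity (on this read-out higher numbers stand for higher lipophilicity and lower numbers for lower lipophilicity), compound 2 `COc1ccccc1C1=NC(c2ccccc2)CO1` gives 3.76 and compound 1 `Clc1cccc(Cl)c1C1=NC(c2ccccc2)CO1` gives 3.69, so the two stand within the scatter of each other. Compound 3 `CCSc1ccccc1C1=NC(c2ccccc2)CO1` has not yet been measured. It carries ethylsulfanyl in place of methoxy on an aromatic carbon. Going by the values given here, no measured pair shows a comparable change, so the expectation rests on the structural change alone. In this assay, a rise beyond the scatter is expected, with an estimated step of a number 0.74 log units higher from compound 2 to compound 3 (beyond the scatter). For compound 3 the estimated value is 4.5, with an expected range from 4.1 to 5.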

Compound 3, partition coefficient: 4.04
The estimate for compound 3 lay 0.46 log units above the measured number, and the stated range ends above it.
By their numbers in this assay, from the lowest: compounds 1, 2 and 3 (each within the scatter of the next, the first and the last beyond it).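

In this assay, ethylsulfanyl in place of methoxy on an aromatic carbon, ortho to a large group, gives a number 0.28 log units higher from compound 2 to compound 3 (within the scatter). Going by these compounds alone, this is the only step between compounds differing in one place, and on this single pair the read-out does not separate the two groups at this position. No measurement at hand bears on the reason for this result. The compounds shown leave open whether a longer chain or an amine in the same place would move the number beyond the scatter. They also leave open whether the step would be the same on another core.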